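The compounds below may be only part of what the source reports. "The series", "measured", "known", "first", "only" and "open" are said of these compounds alone.

Compound 2 `COc1ccccc1Nc1ncnn1-c1cccc(Cl)c1Cl` stands lowest of the two numbers shown in a functional assay for antagonist activity at P2X purinoceptor 7 (Homo sapiens), read by FLIPR and calcium flux (a higher number here means a weaker inhibitor, a lower number a stronger inhibitor), where compound 2 gives 102 nM. For the measured compounds named here, its only measured neighbour is compound 1 `Clc1cccc(-n2ncnc2Nc2ccccc2)c1Cl`, which in this assay gives 363 nM; the step of a 3.6-fold lower number from compound 1 to compound 2 (0.55 log units; beyond the scatter) is the single comparison available, methoxy in place of hydrogen on an aromatic carbon. Compound 3 `FC(F)(F)Oc1ccccc1Nc1ncnn1-c1cccc(Cl)c1Cl` differs from compound 2 in one place: trifluoromethyl in place of methyl on an oxygen on an aromatic ring. Going by the values given here, no measured step bears directly on this change; the one step known concerns the arrival of the methoxy group itself, not what sits on its oxygen, so that step offers only a loose guide. In this assay compound 3 is therefore expected to land near compound 2, with a step of a 1.3-fold higher number from compound 2 to compound 3 (0.11 log units; within the scatter) that may not go beyond the usual scatter. The estimate for compound 3 in this assay is 130 nM, within a range from 45 nM to 380 nM.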

Compound 3, half-maximal inhibitory concentration: 617 nM
Estimate against measurement, compound 3: 4.7-fold (0.68 log units) below, outside the stated range (above it).
By their numbers in this assay, from the lowest: compound 2; then compounds 1 and 3 (each within the scatter of the next).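

In this assay the group on this oxygen matters: methoxy to trifluoromethoxy brings a 6.0-fold higher number from compound 2 to compound 3 (0.78 log units; beyond the scatter) and so undoes what the methoxy group gained over the hydrogen of compound 1. Set directly against that hydrogen, the trifluoromethoxy group gives a 1.7-fold higher number from compound 1 to compound 3 (0.23 log units; within the scatter) and thus no separation from compound 1, so among the three groups shown at this place only methoxy stands apart. No measurement shown gives a reason for the step from methoxy to trifluoromethoxy.

As far as these compounds go, whether an ethyl chain, a difluoromethyl group or a plain hydrogen on the same oxygen would side with compound 2 or with compound 3 remains open. Also open, from the compounds shown here alone, is whether the same exchange of methyl for trifluoromethyl would give a step of similar size elsewhere on the shared core.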